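This account rests on a few compounds, and the source may have more. Where it says the series, first, only, none or still open, it means among the compounds named here.

Measured in a physicochemical assay for solubility; a higher number here means a more soluble compound, a lower number a less soluble compound:
- Compound 1 `CN(C)CC(=O)N1CCC(NS(=O)(=O)c2cc(S(=O)(=O)c3ccccc3)ccc2C(F)(F)F)CC1`: 100000 nM
- Compound 2 `CN(C)c1ccc(C(=O)N2CCC[C@H]2C(=O)N2CCC(NS(=O)(=O)c3cc(S(=O)(=O)c4ccccc4)ccc3C(F)(F)F)CC2)cc1`: 100000 nM

Compound 2 stands level with compound 1 in this assay. Compound 3 `CN1CCC[C@H]1C(=O)N1CCC(NS(=O)(=O)c2cc(S(=O)(=O)c3ccccc3)ccc2C(F)(F)F)CC1` differs from compound 2 by one change: methyl in place of (4-(dimethylamino)phenyl)carbonyl on an amine nitrogen in a ring. Among the measured compounds shown here, no step between measured compounds is available to scale this change. Compound 1 at 100000 nM and compound 2 at 100000 nM carry different groups on the shared core yet read alike, so no step beyond the scatter is expected. The expected step is no change at the digits printed from compound 2 to compound 3 (within the scatter). The estimate for compound 3 is 100000 nM, expected between 50000 nM and 110000 nM.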

Compound 3, solubility: 100000 nM
Estimate against measurement, compound 3: no gap at the digits printed; low and high end bracket the measured number.
By their numbers in this assay, from the lowest: compounds 1, 2 and 3 (each within the scatter of the next).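

In this assay, methyl in place of (4-(dimethylamino)phenyl)carbonyl on an amine nitrogen in a ring gives no change at the digits printed from compound 2 to compound 3 (within the scatter) and so shows that a far smaller group at this position reads the same as the large aromatic one. With 1-methylpyrrolidin-2-yl in place of (dimethylamino)methyl on a carbonyl carbon, the result is no change at the digits printed from compound 1 to compound 3 (within the scatter) and the two changes read alike.

As far as these compounds go, whether a carboxylic acid or a longer chain on this ring nitrogen would shift the reading stays open. No measurement shown here offers an explanation for the matching readings.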